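The compounds below may be only part of what the source reports. "The series", "measured", "known", "first", "only" and "open" are said of these compounds alone.

Compound 2, `COc1ccc(Nc2nc(SCc3cn(CC(=O)NC(=O)Nc4ccccn4)nn3)nc(-c3ccc(C)cc3)c2C#N)cc1`, stands at the weaker end of the two measured compounds: in a functional assay on B16-F10 cells (Mus musculus) for inhibition, read by MTT assay, with a stated time of 72 h (a higher number here means a weaker inhibitor, a lower number a stronger inhibitor), compound 2 gives 8750 nM, the highest of the two numbers. Its nearest neighbour is compound 1, `COc1cc(-c2nc(SCc3cn(CC(=O)NC(=O)Nc4ccccn4)nn3)nc(Nc3cccc(Cl)c3)c2C#N)cc(OC)c1OC`, and in this assay compound 1 gives 1420 nM, a gap that lies beyond the usual scatter. Compound 3, `Cc1ccc(-c2nc(SCc3cn(CC(=O)NC(=O)Nc4ccccn4)nn3)nc(Nc3cccc(Cl)c3)c2C#N)cc1`, has not been measured yet. It differs from compound 2 in one place: 3-chlorophenyl in place of 4-methoxyphenyl on a nitrogen on an aromatic ring. Among the measured compounds shown here, no measured pair shows this change on its own, so the size of the step cannot be read from the data. Compound 3 is nonetheless expected to come in somewhat lower than compound 2, with a step of a 2.5-fold lower number from compound 2 to compound 3 (0.40 log units; beyond the scatter) estimated for this assay, though a step within the scatter would not be surprising. For compound 3 the expected value in this assay is therefore 3500 nM, with a range from 1200 nM to 10000 nM.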

Compound 3, half-maximal inhibitory concentration: 7580 nM
Estimate against measurement, compound 3: 2.2-fold (0.34 log units) below; the range from low to high includes it.
By their numbers in this assay, from the lowest: compound 1; then compounds 3 and 2 (each within the scatter of the next).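

In this assay, 3-chlorophenyl in place of 4-methoxyphenyl on a nitrogen on an aromatic ring gives a 1.2-fold lower number from compound 2 to compound 3 (0.06 log units; within the scatter), so with 4-methylphenyl held fixed on the core, these two groups cannot be told apart at this position. The other single change does register: 4-methylphenyl in place of 3,4,5-trimethoxyphenyl on an aromatic carbon, with the 3-chlorophenyl group held fixed, gives a 5.3-fold higher number from compound 1 to compound 3 (0.73 log units; beyond the scatter), a modest step beyond the scatter. Nothing shown accounts for either step.

Whether the two phenyl groups on the nitrogen would also match with 3,4,5-trimethoxyphenyl on the core cannot be read from these compounds. From the compounds shown here alone, how a benzyl or cyclohexyl group would behave on that nitrogen also remains open.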